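This account rests on a few compounds, and the source may have more. Where it says the series, first, only, none or still open, it means among the compounds named here.

For the measured compounds named here, compound 2 `O=C(C1CCCCC1)N1CCC2(CCN(c3nccc(NCc4ccc(Cl)cc4Cl)n3)CC2)C1` gives 3 ug/mL in a physicochemical assay for solubility, read by chemiluminescence, measured as kinetic solubility (on this read-out lower numbers stand for lower solubility and higher numbers for higher solubility), the lowest of the two numbers known so far. Going by the values given here, its only measured neighbour is compound 1 `O=C([C@@H]1CCCCN1)N1CCC2(CCN(c3nccc(NCc4ccc(Cl)cc4Cl)n3)CC2)C1`, which gives 170 ug/mL in this assay; the two are separated by the step of a 57-fold lower number from compound 1 to compound 2 (1.75 log units; beyond the scatter). Compound 3 `Clc1ccc(CNc2ccnc(N3CCC4(CCN(CC5CCCCN5)C4)CC3)n2)c(Cl)c1` has not yet been measured. It differs from compound 2 in one place: (piperidin-2-yl)methyl in place of cyclohexylcarbonyl on an amine nitrogen in a ring. Among the compounds with values here, the one measured step that bears on this change is a 57-fold lower number from compound 1 to compound 2 (1.75 log units; beyond the scatter), in which the piperidin-2-yl of compound 1 gave way to cyclohexyl and the number fell far beyond the scatter. The change to compound 3 runs the other way: a six-membered non-aromatic ring with 1 hetero atom and 1 hydrogen-bond donor comes back in place of a ring of carbon only, and the carbonyl leaves as well. On that basis a large rise in this assay is expected, of about a 67-fold higher number from compound 2 to compound 3 (1.82 log units; beyond the scatter). The estimate for compound 3 is 200 ug/mL, with a range from 60 ug/mL to 500 ug/mL.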

Compound 3, solubility: 182 ug/mL
The estimate for compound 3 lay 1.1-fold (0.04 log units) above the measured number; low and high end bracket the measured number.
By their numbers in this assay, from the lowest: compound 2; then compounds 1 and 3 (each within the scatter of the next).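

In this assay, the large step of a 61-fold higher number from compound 2 to compound 3 (1.78 log units; beyond the scatter) shows that the high number does not depend on keeping the carbonyl at this position, for (piperidin-2-yl)methyl on the amine nitrogen in a ring stands far from cyclohexylcarbonyl even though the link to the ring has changed. The second new step, a 1.1-fold higher number from compound 1 to compound 3 (0.03 log units; within the scatter), adds what the earlier pair could not show: with the piperidin-2-yl ring in place, exchanging (piperidin-2-yl)carbonyl for (piperidin-2-yl)methyl leaves the two compounds level within the scatter, so among these three compounds only the one with the ring of carbon only stands apart, and none goes against this. Nothing at hand explains why these numbers fall as they do.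

The compounds shown leave open whether cyclohexylmethyl on the same nitrogen would read with compound 2 or with compound 1 and compound 3, which would separate the ring from the carbonyl in a way these three cannot. They also leave open whether the piperidin-2-yl ring itself is needed, or whether a piperidin-3-yl, a morpholine or an open-chain amine would give a similar number.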